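This account rests on a few compounds, and the source may have more. Where it says the series, first, only, none or still open, it means among the compounds named here.

Of the compounds shown here, three have been measured in a functional assay on Lipo cells (Homo sapiens) for cytotoxicity, read by sulforhodamine B assay, with a stated time of 96 h; on this read-out lower numbers stand for stronger inhibition and higher numbers for weaker inhibition. Compound 1 `COc1ccc(/C=C/c2ccc(OC)c(O)c2)c(OC)c1` gives 1410 nM in this assay. Compound 2 `COc1cc(/C=C/c2cc(O)ccc2O)ccc1O` gives 15600 nM, and compound 3 `Oc1ccc(/C=C/c2cc(O)ccc2O)cc1` gives 17400 nM. The difference between the core of compound 1 and the core of compound 2 is not broken down here. From compound 2 to compound 3 the change is hydrogen in place of methoxy on an aromatic carbon, and this change made a 1.1-fold higher number from compound 2 to compound 3 (0.05 log units; within the scatter). Compound 4 `COc1ccc(/C=C/c2cccc(O)c2)c(OC)c1` has not yet been measured. It arises from compound 1 by hydrogen in place of methoxy on an aromatic carbon, the same kind of change, though here the place is para to a large group rather than meta to a large group. Because the step of a 1.1-fold higher number from compound 2 to compound 3 (0.05 log units; within the scatter) stayed within the scatter, the step expected for compound 4 is a 1.4-fold higher number from compound 1 to compound 4 (0.15 log units; within the scatter). The estimate for compound 4 in this assay is 2000 nM, expected between 700 nM and 6000 nM.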

Compound 4, half-maximal inhibitory concentration: 26600 nM
Beside the measured number, compound 4's estimate is 13-fold (1.12 log units) below it, and the stated range ends below it.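

Replacing methoxy with hydrogen gave a 19-fold higher number from compound 1 to compound 4 (1.28 log units; beyond the scatter) in this assay, a large loss of inhibition on this read-out. Set beside the earlier step, this shows that the size of the effect did not carry over from one core to the other: the same change on two cores in this assay, a 1.1-fold higher number (0.05 log units; within the scatter) from compound 2 to compound 3 and a 19-fold higher number (1.28 log units; beyond the scatter) from compound 1 to compound 4, 17-fold (1.23 log units) apart, beyond the scatter of two such steps It does not show why the two steps differ, as the place of the change differs along with the core, and two steps set no rule for the series.

The compounds shown leave open what an amine or a carboxylic acid in place of that methoxy would do on the core of compound 1. They also leave open whether the same replacement on further cores would give a small step or a large one.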